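From a Propargyl Amide to a 2,2-Dimethoxyethyl Amide

The source may hold more compounds than are shown below. What is called first, only, known or untested is meant among the compounds shown, and "the series" means these compounds.

In a functional assay on PC-3 cells (Homo sapiens), read by MTT assay, with a stated time of 48 h (on this read-out lower numbers stand for stronger inhibition and higher numbers for weaker inhibition), compound 1 (`CCOC(=O)CN(C)C(=O)c1ccc(C(CC)(CC)c2ccc(OCC(O)C(C)(C)C)c(C)c2)n1CC`) gives 25500 nM and compound 2 (`C#CCNC(=O)c1ccc(C(CC)(CC)c2ccc(OCC(O)C(C)(C)C)c(C)c2)n1CC`) gives 16200 nM on the same read-out. Among the compounds with values here, these are the only two numbers available, and they lie within the scatter of each other, so compound 2 shares a single level with compound 1 and the pair gives no ranking. Compound 3 (`CCn1c(C(=O)NCC(OC)OC)ccc1C(CC)(CC)c1ccc(OCC(O)C(C)(C)C)c(C)c1`) keeps the core of compound 2 and differs in one place (dimethoxymethyl in place of ethynyl on a saturated chain carbon bound to an amide-type nitrogen) with dimethoxymethyl in place of ethynyl on a saturated chain carbon bound to an amide-type nitrogen. The same difference reads as propargylcarbamoyl to (2,2-dimethoxyethyl)carbamoyl. Within the data shown here, one measured step bears on this, an exchange on a carbonyl carbon (a 1.6-fold lower number from compound 1 to compound 2 (0.20 log units; within the scatter)), and on that evidence no step beyond the scatter is expected in this assay and no direction is favoured. Among the measured compounds shown here, no measured step tests dimethoxymethyl itself. The expected step is a 1.0-fold higher number from compound 2 to compound 3 (0.02 log units; within the scatter) and would stay within the scatter. For compound 3 the estimate is 17000 nM with an expected range from 8000 nM to 36000 nM on this read-out.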

Compound 3, half-maximal inhibitory concentration: 14600 nM
For compound 3 the middle estimate is 1.2-fold (0.07 log units) above the measured one; the range from low to high includes it.
By their numbers in this assay, from the lowest: compounds 3, 2 and 1 (each within the scatter of the next).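

In this assay, replacing ethynyl with dimethoxymethyl on a saturated chain carbon bound to an amide-type nitrogen gives a 1.1-fold lower number from compound 2 to compound 3 (0.05 log units; within the scatter) and removes the only triple bond outside aromatic rings, so the level set by compound 2 does not depend on that triple bond. The entering group has 5 heavy atoms and 2 hydrogen-bond acceptors, against 2 heavy atoms and no acceptors in ethynyl, and that difference also leaves the read-out within the scatter. The wider exchange of ((ethoxycarbonyl)methyl)(methyl)amino for (2,2-dimethoxyethyl)amino on a carbonyl carbon gives a 1.7-fold lower number from compound 1 to compound 3 (0.24 log units; within the scatter) and thus places all three amides on a single level, though nothing available explains why the number stays there.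

The compounds shown leave open whether an amine, a carboxylic acid or a longer chain on that saturated chain carbon would move the number beyond the scatter. They also leave open whether this single level would hold with a different group on the carbonyl carbon, such as a morpholine amide, or only for the three amides shown here.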